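This account rests on a few compounds, and the source may have more. Where it says the series, first, only, none or still open, it means among the compounds named here.

In an ADME assay on L02 cells (Homo sapiens) for inhibition, read by CCK-8 assay, with a stated time of 48 h (on this read-out higher numbers stand for weaker inhibition of growth and lower numbers for stronger inhibition of growth), the measured compounds read:

- compound 1 (`COc1ccccc1CNc1nc(Nc2ccc(N3CCN(C)CC3)cn2)ncc1Cl`) gives 25500 nM in this list
- compound 2 (`CN1CCN(c2ccc(Nc3ncc(Cl)c(NCc4ccco4)n3)nc2)CC1`) gives 45700 nM in this list

Going by the values given here, compound 2 stands within the scatter of compound 1, the only other compound measured. Compound 3 (`Cc1cccc(Nc2nc(Nc3ccc(N4CCN(C)CC4)cn3)ncc2Cl)c1`) carries 3-methylphenyl in place of (furan-2-yl)methyl on a nitrogen on an aromatic ring. Among the compounds with values here, the one measured step, a 1.8-fold higher number from compound 1 to compound 2 (0.25 log units; within the scatter), put furan-2-yl in place of 2-methoxyphenyl on a saturated chain carbon and stayed within the scatter. Neither measured compound has 3-methylphenyl on that nitrogen, so this step bears on the change only in part. No step beyond the scatter is therefore expected in this assay, in either direction. For compound 3 the estimate is 30000 nM with 10000 nM to 70000 nM as the expected range. This estimate means an expected 1.5-fold lower number from compound 2 to compound 3 (0.18 log units; within the scatter) and nothing more.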

Compound 3, concentration for 50% growth inhibition: 6080 nM
Beside the measured number, compound 3's estimate is 4.9-fold (0.69 log units) above it, and the stated range ends above it.
By their numbers in this assay, from the lowest: compound 3; then compounds 1 and 2 (each within the scatter of the next).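

In this assay, the group on a nitrogen on an aromatic ring proved able to move the read-out beyond the scatter: 3-methylphenyl in place of (furan-2-yl)methyl gave a 7.5-fold lower number from compound 2 to compound 3 (0.88 log units; beyond the scatter) and 3-methylphenyl in place of 2-methoxybenzyl gave a 4.2-fold lower number from compound 1 to compound 3 (0.62 log units; beyond the scatter), each pointing to stronger inhibition of growth. Going by these compounds alone, the two groups that carry a saturated chain carbon on this nitrogen had stayed within the scatter of each other, so compound 3, with its aromatic ring bound directly to the nitrogen, is the first to stand apart. No measurement at hand explains this shift.

The compounds shown do not separate the loss of the chain carbon from the change of ring or the methyl group. Unsubstituted phenyl and 3-methylbenzyl on this nitrogen would bear on that question, and how far the trend extends to other 3-substituted phenyl groups, such as 3-methoxyphenyl, remains open.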